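The source may report more compounds than this note shows. Statements on the series, on what has been measured and on what is new or still open speak of the compounds shown alone.

Notes on the series in an ADME assay on J774 cells (Mus musculus) for cytotoxicity; on this read-out lower numbers stand for an effect already at smaller amounts and higher numbers for an effect only at larger amounts of compound. Compound 1 `COC(=O)c1c[nH]c2cc(OCCOc3ccccc3)ccc2c1=O` stands at > 20000 nM, which is a limit of the assay. Compound 2 `COC(=O)c1c[nH]c2cc(OCc3ccccc3)ccc2c1=O` gives 18900 nM and compound 3 `COC(=O)c1c[nH]c2cc(OCCc3ccccc3)ccc2c1=O` gives 17200 nM, so these two numbers lie within the scatter of each other. Compound 4 `COC(=O)c1c[nH]c2cc(OCCCc3ccccc3)ccc2c1=O` follows from compound 3 by benzyl in place of phenyl on a saturated chain carbon, two bonds along the chain from an oxygen on an aromatic ring. Among the measured compounds shown here, the closest precedent is the same exchange on a saturated chain carbon bound to an oxygen on an aromatic ring, a 1.1-fold lower number from compound 2 to compound 3 (0.04 log units; within the scatter). The steps of an at least 1.0-fold lower number from compound 1 to compound 2 (0.02 log units; that floor lies within the scatter) and an at least 1.1-fold lower number from compound 1 to compound 3 (0.06 log units; that floor lies within the scatter) start from the limit and give only floors. No step beyond the scatter is therefore expected in this assay. Compound 4 is estimated at 15500 nM, with an expected range of 8500 nM to 20000 nM. That estimate means a 1.1-fold lower number from compound 3 to compound 4 (0.05 log units; within the scatter) as the expected step.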

Compound 4, half-maximal effective concentration: 1480 nM
Compound 4: the middle estimate sits 10-fold (1.02 log units) above what was measured; measured number below the stated range.
By their numbers in this assay, from the lowest: compound 4; then compounds 3 and 2 (each within the scatter of the next). At a limit, above all of these: compound 1.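

In this assay, benzyl in place of phenyl on a saturated chain carbon, two bonds along the chain from an oxygen on an aromatic ring, gives a 12-fold lower number from compound 3 to compound 4 (1.07 log units; beyond the scatter), while the same exchange on a saturated chain carbon bound to an oxygen on an aromatic ring gave only a 1.1-fold lower number from compound 2 to compound 3 (0.04 log units; within the scatter). Chain extension is thus not uniform across these compounds, and a 13-fold lower number from compound 2 to compound 4 (1.11 log units; beyond the scatter) confirms the sharp change at compound 4. Compound 1 stands at a limit, so an at least 13-fold lower number from compound 1 to compound 4 (1.13 log units; beyond the scatter) gives only a floor: the limit of > 20000 nM in this assay, at which 1 of the 4 values shown sits.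

On these data alone, whether a longer chain ending in phenyl stays at the level of compound 4 remains open. So does the effect of an amine in place of the terminal phenyl.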